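The source may hold more compounds than are shown below. What is called first, only, known or untested is meant among the compounds shown, and "the series" means these compounds.

Measured so far:
- compound 1, `COc1ccc(NC(=O)c2ccccc2C)nc1`: 23 uL/min
- compound 2, `Cc1c(F)cccc1C(=O)Nc1ccccn1`: 58 uL/min

Among the measured compounds shown here, in an ADME assay (liver) for metabolic stability, with Liver microsome (Homo sapiens) as the target, read by LC-MS, using microsomes, with a stated time of 60 min, tested at 1 uM (a higher number here means faster removal of the compound, a lower number slower removal), compound 1 gives the lowest of the two numbers so far; compound 2 sits a bit higher, and that gap lies beyond the scatter. Compound 3, `Cc1ccccc1C(=O)Nc1ccc(F)cn1`, is not yet measured. Its change from compound 1 is fluoro in place of methoxy on an aromatic carbon. For the measured compounds named here, no measured pair shows this change, so the step is not calibrated. On the shared core, with the methoxy gone, a step from compound 1 to compound 3 of a 1.4-fold lower number from compound 1 to compound 3 (0.13 log units; within the scatter) is expected, downward but small. Compound 3 is estimated at 17 uL/min, with a likely range of 7 uL/min to 42 uL/min.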

Compound 3, intrinsic clearance in a liver preparation (reported as CLH), per the amount of preparation that the assay uses in the Liver microsome assay: 43 uL/min
For compound 3 the middle estimate is 2.5-fold (0.40 log units) below the measured one; the whole stated range lies below it.
By their numbers in the Liver microsome assay, from the lowest: compounds 1, 3 and 2 (each within the scatter of the next, the first and the last beyond it).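

At this position, para to a large group, fluoro in place of methoxy now has a measured size in the Liver microsome assay (a 1.9-fold higher number from compound 1 to compound 3 (0.27 log units; within the scatter)), so that read-out does not tell the two groups apart. In a physicochemical assay for lipophilicity, read by HPLC, at pH 7.4 (on this read-out higher numbers stand for higher lipophilicity and lower numbers for lower lipophilicity), compound 1 gives 2.5 and compound 3 gives 2.7, and the step (a number 0.20 log units higher from compound 1 to compound 3 (within the scatter)) does not tell them apart either. No measurement at hand bears on the reason for either step. On these data alone, whether an amine or a carboxylic acid at this position would move the Liver microsome assay beyond the scatter stays open, as does whether this step carries over to another core.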